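This account rests on a few compounds, and the source may have more. Where it says the series, first, only, none or still open, it means among the compounds named here.

Working notes on the series

Of the compounds shown here, three of the shared core have been measured in a functional assay on HEK293 cells for agonist activity at G-protein coupled receptor 39 (Homo sapiens), read by scintillation proximity assay and inositol phosphate accumulation, with a stated time of 75 min; a lower number here means that less compound is needed, a higher number that more compound is needed for the effect. Compound 1 `Cc1nn(-c2ncnc3nc[nH]c23)c2c1C(OCc1ccccc1C#N)CC(=O)N2` gives 127 nM. Compound 2 `Cc1nn(-c2ncnc3nc[nH]c23)c2c1C(OCc1ccc(C(C)C)cc1)CC(=O)N2` gives 1690 nM, and compound 3 `Cc1nn(-c2ncnc3nc[nH]c23)c2c1C(c1ccc(OC(C)C)cc1)CC(=O)N2` gives 2700 nM. Compound 2 thus stands second highest of the three numbers; its nearest neighbour is compound 3, and that gap lies within the scatter, while its furthest is compound 1, with a 13-fold higher number from compound 1 to compound 2 (1.12 log units; beyond the scatter).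

Compound 4 `COc1ccc(CCOC2CC(=O)Nc3c2c(C)nn3-c2ncnc3nc[nH]c23)cc1` is not yet measured. It differs from compound 2 in one place: 4-methoxybenzyl in place of 4-isopropylphenyl on a saturated chain carbon bound to an oxygen on a saturated carbon.

Two measured steps exist. The step from compound 1 to compound 2, a 13-fold higher number from compound 1 to compound 2 (1.12 log units; beyond the scatter), sits at the same place as the change to compound 4 and shows that the aryl group on that chain carbon moves this assay strongly. The step of a 21-fold higher number from compound 1 to compound 3 (1.33 log units; beyond the scatter) alters a different place and bears only indirectly. Neither step tests a methoxybenzyl or a longer chain, so direction is open; the expectation for compound 4 is a step of a 1.7-fold lower number from compound 2 to compound 4 (0.23 log units; within the scatter), not clearly beyond the scatter. Compound 4 is estimated at 1000 nM, within the range 250 nM to 4000 nM.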

Compound 4, half-maximal effective concentration: 70 nM
The estimate for compound 4 lay 14-fold (1.15 log units) above the measured number; measured number outside the range, below it.
By their numbers in this assay, from the lowest: compounds 4 and 1 (each within the scatter of the next); then compounds 2 and 3 (each within the scatter of the next).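

Working notes, continued: in this assay, the position on a saturated chain carbon bound to an oxygen on a saturated carbon is not simply sensitive to any replacement of 2-cyanophenyl, since 4-methoxybenzyl in place of 4-isopropylphenyl gives a 24-fold lower number from compound 2 to compound 4 (1.38 log units; beyond the scatter), although both groups count 9 heavy atoms and one six-membered aromatic ring of carbon only. A nitrile is also not needed at this position for a number in this range, as the change from 2-cyanophenyl to 4-methoxybenzyl gives a 1.8-fold lower number from compound 1 to compound 4 (0.26 log units; within the scatter), which lies within the scatter. No measurement at hand accounts for the difference between these groups.

The change read one bond further out, 4-isopropylbenzyl to 2-(4-methoxyphenyl)ethyl, alters both the chain and the group on the aromatic ring, so the shown compounds cannot assign the large step to either alteration alone. A 2-(4-isopropylphenyl)ethyl group would test the chain with the isopropyl group kept, a 4-methoxyphenyl group would test the methoxy group on the shorter chain, and a 3-(4-methoxyphenyl)propyl group or a terminal amine would show how far this position extends.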